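Cyano to dichlorophenyl on the side chain: working notes

This account rests on a few compounds, and the source may have more. Where it says the series, first, only, none or still open, it means among the compounds named here.

Values in an ADME assay on BJ cells (Homo sapiens) for cytotoxicity, with a stated time of 72 h; a higher number here means that more compound is needed for the effect, a lower number that less compound is needed
compound 1 `C=C[C@@](C)(/C=C/c1ccc(O)c(CO)c1)CCC=C(C)C` | > 36600 nM (a limit)
compound 2 `C=C[C@@](C)(/C=C/c1ccc(O)c(/C=C/C#N)c1)CCC=C(C)C` | > 36600 nM (a limit)

Compound 2 gives > 36600 nM in this assay, and this value is a limit of the assay, not a number. For the measured compounds named here, the same is true of the series so far: the limit of > 36600 nM in this assay, at which 2 of the 2 values shown sit. Going by the values given here, the only measured step is a step that the two limits leave unreadable from compound 1 to compound 2, so it offers no size to carry forward.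

The next compound is compound 3 `C=C[C@@](C)(/C=C/c1ccc(O)c(/C=C/c2ccc(Cl)c(Cl)c2)c1)CCC=C(C)C`, with 3,4-dichlorophenyl in place of cyano on a double-bonded chain carbon bound to a double-bonded chain carbon. The counted change is 3,4-dichlorophenyl in place of cyano on a double-bonded chain carbon bound to a double-bonded chain carbon. This exchange brings in a whole aromatic ring, whereas the step from compound 1 to compound 2 did not, so that step is a weak guide here. In this assay, the expectation is that compound 3 stays close to the limit, with any readable shift towards less compound being needed. For compound 3 the estimated value is 30000 nM, with an expected range from 9000 nM to 60000 nM. This estimate means an expected at least 1.2-fold lower number from compound 2 to compound 3 (0.08 log units; that floor lies within the scatter), and a further report of only a limit would be no surprise.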

Compound 3, half-maximal effective concentration: > 13000 nM
Compound 3 ended at the assay's limit (the forecaster's own chance of this, stated with the estimate: 55%); the middle value lies beyond the limit too.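

In this assay compound 3 gives > 13000 nM, which is a limit of the assay and not a number. For the compounds shown here, compound 2 also stands at a limit, so no step from compound 2 to compound 3 can be read. The compounds shown leave open whether 3,4-dichlorophenyl in place of cyano changes the read-out at all.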